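The source may report more compounds than this note shows. Statements on the series, on what has been measured and on what is new or still open speak of the compounds shown alone.

Measured in an ADME assay on HepG2 cells (Homo sapiens) for cytotoxicity, read by MTT assay, with a stated time of 48 h; a higher number here means a weaker inhibitor, a lower number a stronger inhibitor:
- compound 1 `O=S(=O)(c1cccc(-c2ccc3ncnc(Nc4ccc(OCc5cccc(F)c5)c(Cl)c4)c3c2)c1)N1CCCC1`: > 15000 nM
- compound 2 `O=S(=O)(c1ccc(-c2ccc3ncnc(Nc4ccc(OCc5ccccc5)c(Cl)c4)c3c2)cc1)N1CCOCC1`: > 15000 nM

Both entries are limits of the assay and not numbers. Compound 2 stands at > 15000 nM, which is a limit. Among the measured compounds shown here, the whole series so far sits at one point: the limit of > 15000 nM in this assay, at which 2 of the 2 values shown sit.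

Compound 3 `O=S(=O)(c1ccc(-c2ccc3ncnc(Nc4ccc(OCc5cccc(Cl)c5)c(Cl)c4)c3c2)cc1)N1CCOCC1` keeps the structure of compound 2 except for one change, benzyloxy to (3-chlorobenzyl)oxy, with chloro in place of hydrogen on an aromatic carbon. For the measured compounds named here, no measured step in this assay shows what this change does, so the expectation rests on the limit reached by compound 2 and compound 1. No shift beyond the usual scatter is expected, and no direction is favoured. The expected a number no higher from compound 2 to compound 3 (the limit leaves the size open) is therefore small. A further report as a limit is the likeliest outcome. Compound 3 is estimated at 15000 nM, with an expected range from 7000 nM to 30000 nM.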

Compound 3, half-maximal inhibitory concentration: > 15000 nM
Compound 3: only a limit was reported (the forecaster's own chance of this, stated with the estimate: 70%); the middle value sits exactly at the limit.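

No step can be read from compound 2 to compound 3, since both are reported only as limits: the limit of > 15000 nM in this assay, at which 3 of the 3 values shown sit.

The compounds shown leave open what chloro in place of hydrogen does, and at what concentration any of the three would reach half-maximal inhibition in this assay.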